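A few compounds are considered here, and "the series" means these few. Any claim that something is new, unique, unknown or untested is made for them only; others in the source may bear on it.

Of the compounds shown here, two sharing one core have been measured in an ADME assay for permeability, using PAMPA, at pH 7.4; on this read-out lower numbers stand for lower permeability and higher numbers for higher permeability. Compound 1 `Cc1cc(NC(=O)Nc2ccccc2C(F)(F)F)c2ccccc2n1` gives 945 10^-6 cm/s, and compound 2 `CC(=O)c1ccc(NC(=O)Nc2cc(C)nc3ccccc23)cc1` gives 473 10^-6 cm/s. Compound 2 stands lowest of the two numbers, yet its gap to compound 1 lies within the usual scatter, so the two cannot be told apart. Compound 3 `Cc1cc(NC(=O)Nc2ccc(OC(F)(F)F)cc2)c2ccccc2n1` has not been measured; it differs from compound 2 by trifluoromethoxy in place of acetyl on an aromatic carbon. Among the compounds with values here, no measured step of this kind exists to lean on, so only a modest rise in this assay is expected: a 1.7-fold higher number from compound 2 to compound 3 (0.23 log units; within the scatter). Compound 3 is thus estimated at about 800 10^-6 cm/s, between 400 10^-6 cm/s and 1600 10^-6 cm/s.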

Compound 3, apparent permeability: 531 10^-6 cm/s
For compound 3 the middle estimate is 1.5-fold (0.18 log units) above the measured one; the range from low to high includes it.
By their numbers in this assay, from the lowest: compounds 2, 3 and 1 (each within the scatter of the next).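

At this position, on an aromatic carbon para to a large group, trifluoromethoxy in place of acetyl gives a 1.1-fold higher number from compound 2 to compound 3 (0.05 log units; within the scatter) in this assay. This first readable step shows that exchanging these two groups, with the same count of hydrogen-bond acceptors but more heavy atoms entering, leaves compound 2 and compound 3 indistinguishable on this read-out. No supporting measurement is available to explain this result. Still open, from the compounds shown here alone, is whether an amine or a carboxylic acid at this position would give a step beyond the scatter.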